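From Amide Nitrogen to Ester Oxygen on the Shared Core

This account rests on a few compounds, and the source may have more. Where it says the series, first, only, none or still open, it means among the compounds named here.

Compound 1 `CCN(CC)CCCNC(=O)c1ccc(C(CC)(CC)c2ccc(OCC(=O)C(C)(C)C)c(C)c2)n1CC` gives 22 nM in an assay on HL-60 cells for agonist activity at vitamin D3 receptor (Homo sapiens), read by microscopy, with a stated time of 96 h; a lower number here means that less compound is needed, a higher number that more compound is needed for the effect. Compound 2 `CCn1c(C(=O)Nc2cccc(C(F)(F)F)c2)ccc1C(CC)(CC)c1ccc(OCC(=O)C(C)(C)C)c(C)c1` reaches only a limit of this assay, > 50000 nM. Going by the values given here, the sole measured step, an at least 2200-fold higher number from compound 1 to compound 2 (3.35 log units; beyond the scatter), is large. Compound 2 therefore stands at the limit of > 50000 nM in this assay, at which 1 of the 2 values shown sits. Compound 3 `CCOC(=O)c1ccc(OC(=O)c2ccc(C(CC)(CC)c3ccc(OCC(=O)C(C)(C)C)c(C)c3)n2CC)cc1` is not yet measured; it differs from compound 2 by 4-(ethoxycarbonyl)phenoxy in place of (3-(trifluoromethyl)phenyl)amino on a carbonyl carbon. Among the compounds with values here, no measured step covers this exact change, and the one measured step is a large loss in this assay. Compound 3 is expected near 30000 nM, within 3000 nM to 100000 nM. The step of an at least 1.6-fold lower number from compound 2 to compound 3 (0.22 log units; that floor lies within the scatter) is thus an estimate, not a result.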

Compound 3, half-maximal effective concentration: 45600 nM
Beside the measured number, compound 3's estimate is 1.5-fold (0.18 log units) below it, and the stated range covers the measured number.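

With 4-(ethoxycarbonyl)phenoxy on the carbonyl carbon, the number remains far from that of compound 1: a 2100-fold higher number from compound 1 to compound 3 (3.32 log units; beyond the scatter). A high number in this series therefore needs neither the amide hydrogen nor the trifluoromethyl group of compound 2. Read against a limit of the assay, an at least 1.0-fold lower number from compound 2 to compound 3 (0.04 log units; that floor lies within the scatter) sets no order between the two compounds.

Going by these compounds, whether the diethylamino end of compound 1 or its propyl chain matters more remains open. A plain butyl amide or a carboxylic acid at this carbonyl carbon could separate these in this assay.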